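Cyano for methylsulfonyl: what to expect of compound 4

The source may hold more compounds than are shown below. What is called first, only, known or untested is meant among the compounds shown, and "the series" means these compounds.

In an ADME assay on MT4 cells (Homo sapiens) for cytotoxicity, read by MTT assay, with a stated time of 5 days (a lower number here means that less compound is tolerated, a higher number that more compound is tolerated), compound 1 `Cc1cc(C#N)cc(C)c1Oc1nc(NC2CCCN(Cc3ccc(C(N)=O)cc3)C2)nc2ccsc12` gives 19500 nM, compound 2 `Cc1cc(C#N)cc(C)c1Oc1nc(NC2CCC(NCc3ccc([N+](=O)[O-])cc3)CC2)nc2ccsc12` gives 54400 nM and compound 3 `Cc1cc(C#N)cc(C)c1Oc1nc(NC2CCC(NCc3ccc(S(C)(=O)=O)cc3)CC2)nc2ccsc12` gives 75200 nM. Compound 3 therefore stands level with compound 2 within the scatter, while compound 1 has a lower number, with a gap beyond the scatter.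

The next compound is compound 4 `Cc1cc(C#N)cc(C)c1Oc1nc(NC2CCC(NCc3ccc(C#N)cc3)CC2)nc2ccsc12`, which differs from compound 3 in one place: cyano in place of methylsulfonyl on an aromatic carbon. Cyano takes the place of methylsulfonyl on an aromatic carbon, para to a large group.

Within the data shown here, one measured step bears on this change: a 1.4-fold higher number from compound 2 to compound 3 (0.14 log units; within the scatter), with methylsulfonyl in place of nitro on an aromatic carbon. Among the measured compounds shown here, that exchange stayed within the scatter, but it is a single step, and no measured compound carries cyano. No change beyond the scatter is therefore expected, and the expected step is a 1.4-fold lower number from compound 3 to compound 4 (0.14 log units; within the scatter). For compound 4 the estimated value is 55000 nM, with an expected range of 25000 nM to 100000 nM.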

Compound 4, half-maximal cytotoxic concentration: 5150 nM
The estimate for compound 4 lay 11-fold (1.03 log units) above the measured number; measured number below the stated range.
By their numbers in this assay, from the lowest: compound 4; then compound 1; then compounds 2 and 3 (each within the scatter of the next).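

In this assay this place on the aromatic ring proves sensitive to the group it carries: the change gives a 15-fold lower number from compound 3 to compound 4 (1.16 log units; beyond the scatter) and, against the nitro compound, an 11-fold lower number from compound 2 to compound 4 (1.02 log units; beyond the scatter) as well. So far the only exchange at this place had stayed within the scatter (a 1.4-fold higher number from compound 2 to compound 3 (0.14 log units; within the scatter)), so methylsulfonyl and nitro do not show how far the number can move here, and cyano is the first group to lower it clearly. Nothing measured here explains why cyano stands apart from the other two groups.

From the compounds shown here alone, it remains open whether the low number belongs to cyano alone or would also appear with a chlorine atom, a methoxy group or an amine at this place. Whether cyano would act the same way in the different amine portion of compound 1 also cannot be read from these compounds.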